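Swapping an Acid Arm for an Amide on Compound 3

This account rests on a few compounds, and the source may have more. Where it says the series, first, only, none or still open, it means among the compounds named here.

Measured so far:
compound 1 `O=C(CN(c1nc(Cl)nc2[nH]cnc12)C1CC1)NCC(=O)OCc1ccccc1` gives 41.9% in a functional assay on the whole organism (Tail, strain ICR) with Mus musculus as the target, in the tail flick test, with a stated time of 60 min, at a dose of 25 umol/kg by the oral route; on this read-out higher numbers stand for a stronger effect at the one dose given and lower numbers for a weaker effect.
compound 2 `O=C(CN(c1nc(Cl)nc2[nH]cnc12)C1CC1)N[C@@H](CCC(=O)OCc1ccccc1)C(=O)OCc1ccccc1` gives 53.7%.
compound 3 `O=C(O)CC[C@H](NC(=O)CN(c1nc(Cl)nc2[nH]cnc12)C1CC1)C(=O)O` gives 33.3%.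

Compound 3 stands lowest of the three numbers; its gap to compound 1 lies within the scatter, its gap to compound 2 beyond it. Compound 4 `NC(=O)C[C@H](NC(=O)CN(c1nc(Cl)nc2[nH]cnc12)C1CC1)C(=O)O` arises from compound 3 by carbamoyl in place of carboxymethyl on a saturated chain carbon, two bonds along the chain from an amide-type nitrogen and a carbonyl carbon. Going by the values given here, the only single-place step measured, a number 11.8 percentage points higher from compound 1 to compound 2 (beyond the scatter), adds a group at a different position rather than replacing one, so it bears only loosely on this change. Compound 2 and compound 3 differ in several places, and their two values show nothing that maps onto this swap. Among the compounds with values here, with no matching step, compound 4 is expected near the starting point, at 35%, within 15% to 55%. The step of a number 1.7 percentage points higher from compound 3 to compound 4 (within the scatter) is thus estimated to stay within the scatter.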

Compound 4, a percentage reported as activity, at one dose (the size of the read-out at that dose, not a potency): 43.1%
Beside the measured number, compound 4's estimate is 8.1 percentage points below it, and the stated range covers the measured number.
By their numbers in this assay, from the lowest: compounds 3, 1 and 4 (each within the scatter of the next); then compound 2.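

In this assay the swap of carboxymethyl for carbamoyl on this saturated chain carbon gives a number 9.8 percentage points higher from compound 3 to compound 4 (within the scatter) and so shows that this position accepts a direct replacement of its acid arm with no change beyond the scatter. The earlier single-place step only added a group, so it did not test a replacement here. No measurement shown accounts for this result. Still open, going by these compounds, is how an amine or a longer chain ending in the same amide would read at this position.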